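A few compounds are considered here, and "the series" means these few. Any claim that something is new, unique, unknown or untested is made for them only; others in the source may bear on it.

Measured in a functional assay on NZB5 cells (Homo sapiens) for inhibition, read by thymidine incorporation, with a stated time of 5 days; a lower number here means a stronger inhibitor, a higher number a weaker inhibitor:
compound 1 `Cc1ccc(C)c(S(=O)(=O)N(C)/N=C/c2cnn3ccc(C#N)cc23)c1`: 2100 nM
compound 2 `CN(/N=C/c1cnn2ccc(C#N)cc12)S(=O)(=O)c1cc([N+](=O)[O-])ccc1F`: 480 nM
compound 3 `CN(/N=C/c1cnn2ccc(C#N)cc12)C(=O)c1cccc([N+](=O)[O-])c1`: 1800 nM

Compound 2, at 480 nM, holds the lowest of the three numbers, and both compound 3 at 1800 nM and compound 1 at 2100 nM lie beyond the scatter from it. Compound 4 `COc1ccc([N+](=O)[O-])cc1S(=O)(=O)N(C)/N=C/c1cnn2ccc(C#N)cc12` has methoxy in place of fluoro on an aromatic carbon, para to a nitro group: methoxy in place of fluoro on an aromatic carbon. For the measured compounds named here, no two measured compounds differ in one place only, so the data offer no direct guide to this change. In this assay a modest loss of inhibition is expected, a 1.5-fold higher number from compound 2 to compound 4 (0.16 log units; within the scatter), and it may not clear the scatter. For compound 4 the estimated value is 700 nM, with an expected range of 220 nM to 2300 nM.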

Compound 4, half-maximal inhibitory concentration: 90 nM
The estimate for compound 4 lay 7.8-fold (0.89 log units) above the measured number, outside the stated range (below it).
By their numbers in this assay, from the lowest: compound 4; then compound 2; then compounds 3 and 1 (each within the scatter of the next).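

In this assay, for the compounds shown here, methoxy in place of fluoro on an aromatic carbon para to a nitro group gives a 5.3-fold lower number from compound 2 to compound 4 (0.73 log units; beyond the scatter), the only comparison here that changes one place. It shows that this carbon, ortho to a large group, takes the larger methoxy with a gain rather than a loss of inhibition. Nothing shown here accounts for this gain.

From the compounds shown here alone, whether an ethoxy group, a longer alkoxy chain or an amine on this carbon would extend the gain stays open. So does whether methoxy would give the same gain without the nitro group.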